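The source may report more compounds than this note shows. Statements on the series, on what has been measured and on what is new or still open speak of the compounds shown alone.

Compound 1, `C=CCn1c(=O)/c(=C\c2ccc(Cl)c(Cl)c2)[nH]c(=O)/c1=C\c1ccccc1`: in a functional assay on U-937 cells (Homo sapiens) for cytotoxicity, read by CCK-8 assay, with a stated time of 72 h (a lower number here means a stronger inhibitor, a higher number a weaker inhibitor), compound 1 gives "not active" (no number reported).
Compound 2, `C=CCn1c(=O)/c(=C\c2cccc(F)c2)[nH]c(=O)/c1=C\c1ccccc1OC`: in this assay compound 2 gives 2500 nM.
Compound 3, `C=CCn1c(=O)/c(=C\c2cccc(Br)c2)[nH]c(=O)/c1=C\c1cccc(Br)c1`: in this assay compound 3 gives "not active" (no number reported).

Compound 2 is the only one of the three that returns a number at all; compound 1 and compound 3 came back without one. Compound 2 therefore stands alone, with nothing measured to rank it against.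

Compound 4, `C=CCn1c(=O)/c(=C\c2ccccc2C(F)(F)F)[nH]c(=O)/c1=C\c1ccccc1OC`, is built from compound 2 by one exchange: 2-(trifluoromethyl)phenyl in place of 3-fluorophenyl on a double-bonded chain carbon bound to an aromatic carbon. Among the compounds with values here, no pair of measured compounds carries this same exchange, so there is no measured step to lean on; the only guidance is that two of three compounds gave no number, which makes an outcome without a number a real possibility for compound 4 as well.

The step from compound 2 to compound 4 in this assay is expected to be a weakening of moderate size, somewhat beyond the ordinary scatter, as a 1.8-fold higher number from compound 2 to compound 4 (0.26 log units; within the scatter) states. On that basis compound 4 is estimated at 4500 nM, with a plausible range from 1500 nM to 15000 nM.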

Compound 4, half-maximal inhibitory concentration: 1500 nM
For compound 4 the middle estimate is 3.0-fold (0.48 log units) above the measured one; measured number inside the range.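

In this assay, putting 2-(trifluoromethyl)phenyl in place of 3-fluorophenyl on a double-bonded chain carbon bound to an aromatic carbon gives a 1.7-fold lower number from compound 2 to compound 4 (0.22 log units; within the scatter), so the two compounds cannot be told apart in this test. Within the data shown here, until now, compound 2 was the only compound with a number, and compound 4 shows that a number does not depend on that one group: this place can hold a group of 10 heavy atoms instead of 7, with fluorine still present but in a different group, and the reading stays within the usual scatter. Nothing among the available data explains why the two readings match, so this result describes what happens at this place without giving a reason for it.

Compound 1 and compound 3 differ from compound 2 and compound 4 in more than one place, so their missing numbers cannot be tied to any single change and their steps cannot be read. These compounds also leave open whether a reading would survive at this place if the aromatic ring gave way to a non-aromatic group, or if the ring carried an amine or a carboxylic acid.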